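The source may hold more compounds than are shown below. What is called first, only, known or untested is meant among the compounds shown, and "the series" means these compounds.

Measured so far in a functional assay on B16 cells (Mus musculus) for cytotoxicity, read by MTT assay, with a stated time of 72 h; a lower number here means a stronger inhibitor, a higher number a weaker inhibitor: compound 1 `COc1c(OCCCCN2CCN(C)CC2)cc(O)c2c(=O)cc(-c3ccc(F)cc3)oc12` gives 4320 nM; compound 2 `CN(C)CCCOc1c(OCc2ccccc2)cc(O)c2c(=O)cc(-c3ccccc3)oc12` gives 5420 nM.

Compound 2 carries the nominally higher of the two numbers, but its gap to compound 1 lies within the scatter, so no order between the two can be read. Compound 3 `CCN(CC)CCCCOc1c(OCc2ccccc2)cc(O)c2c(=O)cc(-c3ccccc3)oc12` differs from compound 2 by (diethylamino)methyl in place of dimethylamino on a saturated chain carbon, three bonds along the chain from an oxygen on an aromatic ring. Among the compounds with values here, no step between measured compounds matches this change, so there is nothing to scale an expectation against; a step of no more than the scatter is expected, with no direction favoured. Compound 3 is therefore estimated at 5000 nM, range 2000 nM to 13000 nM, meaning an expected step of a 1.1-fold lower number from compound 2 to compound 3 (0.04 log units; within the scatter) in this assay.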

Compound 3, half-maximal inhibitory concentration: 4880 nM
Estimate against measurement, compound 3: 1.0-fold (0.01 log units) above; low and high end bracket the measured number.
By their numbers in this assay, from the lowest: compounds 1, 3 and 2 (each within the scatter of the next).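

In this assay, within the data shown here, (diethylamino)methyl in place of dimethylamino on a saturated chain carbon, three bonds along the chain from an oxygen on an aromatic ring, gives a 1.1-fold lower number from compound 2 to compound 3 (0.05 log units; within the scatter) in the first one-place comparison of the series. Read as 3-(dimethylamino)propyl to 4-(diethylamino)butyl, this one step combines a longer chain with a different amine, and the number stays within the scatter. No measurement available here bears on this result.

The step does not separate chain length from the ethyl groups on nitrogen. On these data alone, whether a morpholine or a carboxylic acid in place of the amine would also stay within the scatter remains open.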